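The source may report more compounds than this note shows. Statements on the series, on what has been measured and on what is new or still open speak of the compounds shown alone.

Compound 3 `O=C(CSc1nnnn1-c1ccccc1)N/N=c1/scc(-c2ccccc2)n1-c1ccccc1` gives 417 ug/mL in an ADME assay on NIH3T3 cells (Mus musculus) for cytotoxicity, read by MTT assay, with a stated time of 24 h (on this read-out higher numbers stand for weaker inhibition and lower numbers for stronger inhibition), the highest of the two numbers obtained, with compound 2 `O=C(CSc1nnnn1-c1ccccc1)N/N=c1/scc(-c2ccc(Cl)cc2)n1-c1ccccc1` at 313 ug/mL nearest to it; the step of a 1.3-fold higher number from compound 2 to compound 3 (0.12 log units; within the scatter) changes hydrogen for chloro only. Compound 1 `N#Cc1ccc(-c2cs/c(=N/NC(=O)CSc3ncccn3)n2-c2ccccc2)cc1` returns a limit, < 3.9 ug/mL, in this assay. Compound 4 `N#Cc1ccc(-c2cs/c(=N/NC(=O)CSc3nnnn3-c3ccccc3)n2-c2ccccc2)cc1` differs from compound 3 by cyano in place of hydrogen on an aromatic carbon. Among the measured compounds shown here, no measured step changes this group, and the only cyano compound, compound 1, sits at a limit of < 3.9 ug/mL in this assay, at which 1 of the 3 values shown sits, while also differing elsewhere, so its value shows little that carries over. Compound 3 to compound 4 is therefore expected to give a 7.0-fold lower number from compound 3 to compound 4 (0.84 log units; beyond the scatter), a lower number. Compound 4 is estimated at 60 ug/mL, within 3 ug/mL to 400 ug/mL.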

Compound 4, half-maximal inhibitory concentration: 453 ug/mL
The estimate for compound 4 lay 7.6-fold (0.88 log units) below the measured number; the measured number lies above the stated range.
By their numbers in this assay, from the lowest: compounds 2, 3 and 4 (each within the scatter of the next). At a limit, below all of these: compound 1.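

With the 1-phenyl-1H-tetrazol-5-yl group on the sulfur held constant, the change from phenyl to 4-cyanophenyl stays within the scatter in this assay (a 1.1-fold higher number from compound 3 to compound 4 (0.04 log units; within the scatter)), and so does cyano in place of chloro at this position (a 1.4-fold higher number from compound 2 to compound 4 (0.16 log units; within the scatter)). Among the compounds shown here, the one large step instead accompanies 1-phenyl-1H-tetrazol-5-yl in place of pyrimidin-2-yl on the sulfur (an at least 110-fold higher number from compound 1 to compound 4 (2.06 log units; beyond the scatter)). That step starts from a limit, not a number: the limit of < 3.9 ug/mL in this assay, at which 1 of the 4 values shown sits.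

As far as these compounds go, whether an amine or a carboxylic acid at this position would also leave the number unchanged remains open.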